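Silyl ether series: reworking the allyl group

The source may hold more compounds than are shown below. What is called first, only, known or untested is meant among the compounds shown, and "the series" means these compounds.

In a functional assay on A2780 cells (Homo sapiens) for antiproliferative activity, read by sulforhodamine B assay, with a stated time of 48 h (a lower number here means a stronger inhibitor of growth, a higher number a weaker inhibitor of growth), compound 1 `CC(C)(C)[Si](C)(C)O[C@@H]1CCCO[C@@H]1CO` reads > 100000 nM, which is a limit of the assay. Compound 2 `O=C(COC[C@H]1OCCC[C@@H]1O)OCc1ccccc1` reads > 100000 nM, also a limit. Within the data shown here, compound 3 `C=CCOC[C@H]1OCCC[C@H]1O[Si](C)(C)C(C)(C)C` gives 15000 nM, the only true number in the set, while the rest of the set is described by the limit of > 100000 nM in this assay, at which 2 of the 3 values shown sit.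

Compound 4 `CC(C)(C)[Si](C)(C)O[C@@H]1CCCO[C@@H]1CO/C=C/CO` carries 3-hydroxyprop-1-en-1-yl in place of allyl on an oxygen on a saturated carbon. Among the measured compounds shown here, no measured step covers this exact change. The nearest is an at least 6.6-fold lower number from compound 1 to compound 3 (0.82 log units; beyond the scatter), which came with allyl in place of hydrogen at that same oxygen and whose size rests on a limit. Compound 4 alters the group that accompanied this gain, so part of the gain may be lost. A modest move towards a higher number is therefore expected, a 2.0-fold higher number from compound 3 to compound 4 (0.30 log units; within the scatter). For compound 4 the estimated value is 30000 nM, with an expected range of 10000 nM to 100000 nM.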

Compound 4, concentration for 50% growth inhibition: > 100000 nM
Compound 4 gave a limit, no number; the forecaster's own chance of this, stated with the estimate: 30%; at least 3.3-fold (0.52 log units) between middle value and limit.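

In this assay the allyl group on this oxygen does not tolerate every replacement: 3-hydroxyprop-1-en-1-yl in its place gives an at least 6.6-fold higher number from compound 3 to compound 4 (0.82 log units; beyond the scatter), a step beyond the scatter whose size rests on a limit. Compound 4 reads > 100000 nM, which is a limit of the assay. The gain seen with allyl, an at least 6.6-fold lower number from compound 1 to compound 3 (0.82 log units; beyond the scatter), therefore does not extend to this group, and the step from compound 1 to compound 4 cannot be read.

Open, as far as these compounds go, is how a plain propyl chain, a methoxypropyl chain or an aminopropyl chain would read on this oxygen, and whether any of them would keep the activity of compound 3. Most of the set gives no true number to compare against: the limit of > 100000 nM in this assay, at which 3 of the 4 values shown sit.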